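A few compounds are considered here, and "the series" means these few. Any claim that something is new, unique, unknown or untested is made for them only; others in the source may bear on it.

In a functional assay on HCT-116 cells (Homo sapiens) for inhibition, read by sulforhodamine B assay, with a stated time of 48 h (a lower number here means a stronger inhibitor of growth, a higher number a weaker inhibitor of growth), compound 1 `COc1ccc(-c2[nH]c3ccccc3c2/C=C(\C#N)S(=O)(=O)c2ccccc2)cc1` gives 399 nM, the lowest of the three numbers recorded in this assay. Compound 3 `CCOC(=O)C(=Cc1c(-c2ccccc2)[nH]c2ccccc12)C(=O)OCC` gives 4300 nM and compound 2 `COc1ccc2[nH]c(-c3ccccc3)c(C=C(C#N)C#N)c2c1` gives 4400 nM; both lie beyond the scatter above compound 1, and neither differs from compound 1 in a single place. The step to compound 4 `COc1ccc(-c2[nH]c3ccc(OC)cc3c2/C=C(\C#N)S(=O)(=O)c2ccccc2)cc1` is a single change on the shared core: methoxy in place of hydrogen on an aromatic carbon. Going by the values given here, no measured pair in this set isolates such a change, so the step has no direct precedent. Compound 1 is expected to carry most of its potency into compound 4, with a step from compound 1 to compound 4 of a 1.3-fold higher number from compound 1 to compound 4 (0.10 log units; within the scatter) judged small and within the scatter. Compound 4 is therefore estimated at 500 nM, in a range from 150 nM to 1600 nM.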

Compound 4, concentration for 50% growth inhibition: 539 nM
Estimate against measurement, compound 4: 1.1-fold (0.03 log units) below; the range from low to high includes it.
By their numbers in this assay, from the lowest: compounds 1 and 4 (each within the scatter of the next); then compounds 3 and 2 (each within the scatter of the next).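

Going by these compounds alone, this is the first pair in the set that differs in one place: methoxy in place of hydrogen on this aromatic carbon, meta to a fused ring and para to a fused ring, gives a 1.4-fold higher number from compound 1 to compound 4 (0.13 log units; within the scatter) in this assay, so compound 1 and compound 4 cannot be told apart. The position therefore takes methoxy with no step beyond the scatter. No measurement given here bears on the reason for this result. Still open, as far as these compounds go, is whether an amine, a carboxylic acid or a longer alkoxy chain on this carbon would give a similar number.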